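This account rests on a few compounds, and the source may have more. Where it says the series, first, only, none or still open, it means among the compounds named here.

Measured in a functional assay on PC-3 cells (Homo sapiens) for antiproliferative activity, read by MTT assay, with a stated time of 72 h; on this read-out lower numbers stand for stronger inhibition and higher numbers for weaker inhibition:
- compound 1, `COc1cc2ncnc(N3CCCc4ccccc43)c2cc1NC(=O)C=C(C)C`: 6130 nM
- compound 2, `COc1cc2ncnc(N3CCCc4ccccc43)c2cc1NC(=O)/C=C/CN1CCCC1`: 1740 nM

Among the compounds with values here, compound 2 holds the lowest of the two numbers; the only neighbour is compound 1, and the step of a 3.5-fold lower number from compound 1 to compound 2 (0.55 log units; beyond the scatter) separates them, that is, a modest change beyond the scatter when 3-(pyrrolidin-1-yl)prop-1-en-1-yl replaces 2-methylprop-1-en-1-yl on the carbonyl carbon.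

Compound 3, `COc1cc2ncnc(N3CCCc4ccccc43)c2cc1NC(=O)/C=C/CN1CCN(C)CC1`, differs from compound 2 by 4-methylpiperazin-1-yl in place of pyrrolidin-1-yl on a saturated chain carbon bound to a double-bonded chain carbon. Within the data shown here, no measured step concerns this exchange: the single step on record, from compound 1 to compound 2, changes the whole group on the carbonyl carbon, whereas here the chain is kept and only the ring at its end is swapped. With nothing to point either way, no step beyond the scatter is expected in this assay for this change.

On that basis compound 3 is estimated at 1700 nM, with a range from 600 nM to 5000 nM. The estimate amounts to an expected step of a 1.0-fold lower number from compound 2 to compound 3 (0.01 log units; within the scatter), to be checked against the measurement.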

Compound 3, half-maximal inhibitory concentration: 6260 nM
For compound 3 the middle estimate is 3.7-fold (0.57 log units) below the measured one; measured number above the stated range.
By their numbers in this assay, from the lowest: compound 2; then compounds 1 and 3 (each within the scatter of the next).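

In this assay, the ring at the end of the chain is not interchangeable: a 3.6-fold higher number from compound 2 to compound 3 (0.56 log units; beyond the scatter) follows when 4-methylpiperazin-1-yl replaces pyrrolidin-1-yl on the saturated chain carbon bound to a double-bonded chain carbon. The earlier step, a 3.5-fold lower number from compound 1 to compound 2 (0.55 log units; beyond the scatter), therefore cannot be credited to the prop-1-en-1-yl chain with just any ring at its end, since a 1.0-fold higher number from compound 1 to compound 3 (0.01 log units; within the scatter) shows that the chain ending in 4-methylpiperazin-1-yl gives no difference from the 2-methylprop-1-en-1-yl group beyond the scatter; among these compounds, the lower number goes with pyrrolidin-1-yl alone, and compound 3 goes against any wider reading. Nothing available accounts for the difference between the two ring ends.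

The exchange alters ring size, the second ring nitrogen and its methyl group all at once, so these three changes cannot be told apart here. Where a piperidin-1-yl, morpholin-4-yl, unsubstituted piperazin-1-yl or open-chain dimethylamino end would fall relative to these two rings remains open.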